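Adding a Methyl to an Inactive Pair

The source may report more compounds than this note shows. Statements on the series, on what has been measured and on what is new or still open speak of the compounds shown alone.

Compound 1 `Cc1nnc(SCc2cc(=O)c3ccccc3o2)s1` and compound 2 `Nc1nnc(SCc2cc(=O)c3ccccc3o2)s1` share one core and differ in a single group on an aromatic carbon. In a functional assay on SW480 cells (Homo sapiens) for cytotoxicity, read by MTT assay, with a stated time of 72 h (on this read-out lower numbers stand for stronger inhibition and higher numbers for weaker inhibition), compound 1 reaches only the assay limit of > 25000 nM. In this assay compound 2 likewise reaches only the assay limit of > 25000 nM. The step that the two limits leave unreadable from compound 1 to compound 2 therefore cannot be read, since the limit of > 25000 nM in this assay, at which 2 of the 2 values shown sit, places both values at that limit. Compound 2 thus stands at the limit, with no number to rank it against. Compound 3 `Cc1ccc2oc(CSc3nnc(N)s3)cc(=O)c2c1` differs from compound 2 by methyl in place of hydrogen on an aromatic carbon. Among the compounds with values here, no measured step bears on this change, and the one step available is unreadable, so there is no ground to expect a move beyond the scatter in either direction. Compound 3 is therefore expected to stay near the limit, with an estimated step that the limit leaves unreadable from compound 2 to compound 3. The estimate for compound 3 in this assay is 30000 nM, within a range from 10000 nM to 100000 nM.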

Compound 3, half-maximal inhibitory concentration: > 25000 nM
Compound 3: a limit, no number; the forecaster's own chance of this, stated with the estimate: 85%; the middle value lies beyond the limit too.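

In this assay compound 3 reaches only > 25000 nM, which is a limit and not a number. Within the data shown here, no step from compound 2 to compound 3 can be read: the limit of > 25000 nM in this assay, at which 3 of the 3 values shown sit. The compounds shown leave open whether the amino or methyl changes alter cytotoxicity at all, since none gives a number to compare.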